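The source may report more compounds than this note shows. Statements on the series, on what has been measured and on what is new or still open speak of the compounds shown alone.

Among the measured compounds shown here, compound 3 `CCC(CC)OC(=O)C1=C(C)NC(=O)NC1c1ccoc1` stands highest of the three measured members in an assay on membranes from CHO cells for displacement of a labelled ligand from adenosine receptor A1 (Homo sapiens), read by scintillation counting, with a stated time of 60 min, tested at 1 uM (on this read-out higher numbers stand for more inhibition at the one concentration tested (going by the name of the read-out) and lower numbers for less inhibition), where compound 3 gives 17%. Compound 1 `COC(=O)C1=C(C)NC(=O)NC1c1ccoc1` gives 8% and compound 2 `CCCC(=O)C1=C(C)NC(=O)NC1c1ccoc1` gives 1%; the step of a number 9 percentage points higher from compound 1 to compound 3 (within the scatter) lies within the scatter, whereas a number 16 percentage points higher from compound 2 to compound 3 (beyond the scatter) is beyond it. Compound 4 `CC1=C(C(=O)OC2CCCCC2)C(c2ccoc2)NC(=O)N1` differs from compound 3 at the oxygen next to a carbonyl group: cyclohexyl in place of pentan-3-yl on an oxygen next to a carbonyl group. For the measured compounds named here, the one earlier step at that oxygen, a number 9 percentage points higher from compound 1 to compound 3 (within the scatter), was within the scatter, so exchanging the group there has so far moved the read-out little; replacing pentan-3-yl with cyclohexyl is expected to behave alike. Compound 4 is therefore estimated at 20%, in a range from 5% to 40%. The step of a number 3 percentage points higher from compound 3 to compound 4 (within the scatter) is expected to remain within the scatter.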

Compound 4, a percentage reported as inhibition, at one concentration (the size of the read-out at that concentration, not a potency): 15%
Estimate against measurement, compound 4: 5 percentage points above; the measured number falls inside the stated range.
By their numbers in this assay, from the lowest: compounds 2, 1, 4 and 3 (each within the scatter of the next, the first and the last beyond it).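

Cyclohexyl is the first ring at this oxygen, and in this assay it reads like the open chain, with a number 2 percentage points lower from compound 3 to compound 4 (within the scatter), and also like methyl, with a number 7 percentage points higher from compound 1 to compound 4 (within the scatter). Only the exchange on the carbonyl carbon clears the scatter, with a number 14 percentage points higher from compound 2 to compound 4 (beyond the scatter), a second such case beside a number 16 percentage points higher from compound 2 to compound 3 (beyond the scatter). No evidence is at hand on what lies behind these numbers.

From the compounds shown here alone, whether a benzyl group or an amine-bearing chain on this oxygen would move the read-out beyond the scatter stays open.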